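A few compounds are considered here, and "the series" means these few. Any claim that something is new, unique, unknown or untested is made for them only; others in the source may bear on it.

Measured so far in a functional assay on PANC-1 cells (Homo sapiens) for inhibition, read by MTT assay, with a stated time of 24 h, tested at 10 uM; a higher number here means more inhibition at the concentration tested (going by the name of the read-out), a lower number less inhibition:

compound 1 `CC(C)=CCC1Cc2c(OCc3ccccc3)cc(=O)n(CCCO)c2CC1(C)C` gives 11.1%
compound 2 `CC(C)=CCC/C(C)=C/CC1Cc2c(OCc3ccccc3)cc(=O)n(CCCO)c2CC1(C)C` gives 1.5%
compound 3 `CC(C)=CCC/C(C)=C/CC1Cc2c(OCCCNS(=O)(=O)c3ccc(Cl)cc3)cc(=O)n(CCCO)c2CC1(C)C` gives 16.1%

Compound 2 holds the lowest of the three numbers in this assay. Its nearest neighbour is compound 1, which lies within the scatter of it; compound 3 lies beyond the scatter, higher.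

Among the compounds with values here, the only step that can be read from one change alone, a number 9.6 percentage points lower from compound 1 to compound 2 (within the scatter), sits within the scatter and concerns the saturated chain, not the oxygen on the aromatic ring.

Compound 4 `COc1ccc(NC(=O)Oc2cc(=O)n(CCCO)c3c2CC(C/C=C(\C)CCC=C(C)C)C(C)(C)C3)cc1` differs from compound 2 at that oxygen: (4-methoxyphenyl)carbamoyl in place of benzyl on an oxygen on an aromatic ring. Within the data shown here, no measured step bears on exactly this change. Compounds 2 and 3 differ at the same oxygen, though by a different group; the two values show compound 3 higher than compound 2, beyond the scatter. A hydrogen-bond donor and two acceptors enter with the (4-methoxyphenyl)carbamoyl group, as with the group carried by compound 3.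

Expected in this assay for compound 4: a modest rise, a number 10.5 percentage points higher from compound 2 to compound 4 (beyond the scatter), of the order seen between compound 2 and compound 3, without confidence beyond the scatter. The estimate for compound 4 is 12%, with a range from 0% to 30%.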

Compound 4, a percentage reported as inhibition, at one concentration (the size of the read-out at that concentration, not a potency): 0%
Estimate against measurement, compound 4: 12 percentage points above, within the range that was stated.
By their numbers in this assay, from the lowest: compounds 4, 2, 1 and 3 (each within the scatter of the next, the first and the last beyond it).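

In this assay, (4-methoxyphenyl)carbamoyl in place of benzyl on an oxygen on an aromatic ring gives a number 1.5 percentage points lower from compound 2 to compound 4 (within the scatter) and so does not separate from the benzyl group at this position. A hydrogen-bond donor and acceptors in the entering group are therefore not enough on their own to go with a higher number here: compound 3, whose group at the same oxygen also carries them, gives 16.1% and compound 4 gives 0% in this assay with these two values beyond the scatter of each other. No measurement at hand accounts for the gap between these two groups at this oxygen.

Going by these compounds, all four values remain low at the single concentration tested, so it stays open whether any group at this oxygen gives substantial inhibition of these cells. A primary amine or a carboxylic acid at the end of a propyl chain on this oxygen would help show whether the number for compound 3 goes with the chain or with its terminal group.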